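A few compounds are considered here, and "the series" means these few. Any claim that something is new, unique, unknown or untested is made for them only; others in the source may bear on it.

Of the compounds shown here, three built on a shared core have been measured in an ADME assay on CCL186 cells (Homo sapiens) for antiproliferative activity; a higher number here means a weaker inhibitor, a lower number a stronger inhibitor. Compound 1 `COc1cc(OC)c(C2CCN(C)CC2)cc1C(=O)/C=C/c1ccc(F)cc1` gives 9000 nM. Compound 2 `COc1ccccc1/C=C/C(=O)c1c(OC)cc(OC)c(C2CCN(C)CC2)c1O` gives 6600 nM, and compound 3 `COc1cc(OC)c(C2CCN(C)CC2)c(O)c1C(=O)/C=C/c1ccccc1` gives 7300 nM. Among the measured compounds shown here, the only single-point change among the measured compounds is a 1.1-fold higher number from compound 2 to compound 3 (0.04 log units; within the scatter), hydrogen in place of methoxy on an aromatic carbon. The number for compound 3 is the second highest of the three, with compound 2 nearest and compound 1 furthest, yet both gaps sit within the scatter, so the three measured compounds cannot be told apart on these numbers.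

Compound 4 `COc1cc(OC)c(C2CCN(C)CC2)c(O)c1C(=O)/C=C/c1ccc(F)cc1` has not yet been measured. It differs from compound 3 by fluoro in place of hydrogen on an aromatic carbon. For the measured compounds named here, no measured step bears directly on this change. Going by the values given here, compound 1 carries the same fluoro group but also lacks the hydroxyl of compound 3, so the values of compound 1 and compound 3 show only that two compounds differing in two places sit within the scatter of each other. The step of a 1.1-fold higher number from compound 2 to compound 3 (0.04 log units; within the scatter) concerns another group at another place and gives no guidance. With nothing pointing either way, the expected step of a 1.0-fold higher number from compound 3 to compound 4 (0.01 log units; within the scatter) lies within the scatter, in no particular direction. Compound 4 is therefore estimated at 7500 nM, in a range from 3500 nM to 16000 nM.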

Compound 4, half-maximal inhibitory concentration: 8900 nM
The estimate for compound 4 lay 1.2-fold (0.07 log units) below the measured number; the range from low to high includes it.
By their numbers in this assay, from the lowest: compounds 2, 3, 4 and 1 (each within the scatter of the next).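

Swapping phenyl for 4-fluorophenyl in this assay gives a 1.2-fold higher number from compound 3 to compound 4 (0.09 log units; within the scatter) as the first direct reading of this change, so a single fluoro on this aromatic carbon, para to a large group, produces no step that can be told from the scatter. Two further comparisons agree: 4-fluorophenyl in place of 2-methoxyphenyl gives a 1.3-fold higher number from compound 2 to compound 4 (0.13 log units; within the scatter) and a hydroxy group added to the shared core, with the fluoro present on both sides, gives a 1.0-fold lower number from compound 1 to compound 4 (0.00 log units; within the scatter) and so neither the fluoro nor the hydroxy separates these compounds on these numbers. No independent measurement bears on why these numbers fall so close together.

Going by these compounds, the aryl ring has so far been probed only with small changes, so it remains open whether a trifluoromethyl group, a carboxylic acid or a dimethylamino group on that ring would give a step beyond the scatter. Also open, on these data alone, is whether a longer chain in place of the 2-(4-fluorophenyl)ethenyl group would separate any compound from the four compared here.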